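The compounds below may be only part of what the source reports. "The series", "measured", "known", "first", "only" and "open" are said of these compounds alone.

The measured compounds: compound 1 `CCCC(Oc1ccc(-n2cc(Cl)cn2)cc1)c1ccc(C(=O)NCCC(=O)O)cc1` gives 6500 nM in a functional assay on cells for antagonist activity at Glucagon receptor (Homo sapiens), read by cAMP accumulation, in the presence of a further agent that is not named here; on this read-out lower numbers stand for stronger inhibition and higher numbers for weaker inhibition; compound 2 `O=C(O)CCNC(=O)c1ccc(C(Oc2ccc(-n3cc(C(F)(F)F)cn3)cc2)C2CCCC2)cc1` gives 4000 nM in this assay. For compound 3 `CCCC(Oc1ccc(-n2cc(C#N)cn2)cc1)c1ccc(C(=O)NCCC(=O)O)cc1` the assay reports only a limit, > 50000 nM.

On the numbers shown, compound 3 stands at the limit of this assay, reached by the step of an at least 7.6-fold higher number from compound 1 to compound 3 (0.88 log units; beyond the scatter). Compound 4 `CCCC(Oc1ccc(-n2cc(C(F)(F)F)cn2)cc1)c1ccc(C(=O)NCCC(=O)O)cc1` differs from compound 3 by trifluoromethyl in place of cyano on an aromatic carbon. Going by the values given here, no measured step covers this exact change; the nearest evidence is that compound 2, which also bears a trifluoromethyl group, has a number close to that of compound 1, which bears chloro. Compound 4 is therefore expected to regain activity, with a step of an at least 10-fold lower number from compound 3 to compound 4 (1.00 log units; beyond the scatter). The estimate for compound 4 is 5000 nM, between 2000 nM and 15000 nM.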

Compound 4, antagonist equilibrium constant: 5100 nM
Estimate against measurement, compound 4: 1.0-fold (0.01 log units) below; measured number inside the range.
By their numbers in this assay, from the lowest: compounds 2, 4 and 1 (each within the scatter of the next). At a limit, above all of these: compound 3.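

Trifluoromethyl in place of cyano on this aromatic carbon gives an at least 9.8-fold lower number from compound 3 to compound 4 (0.99 log units; beyond the scatter), so on the propyl compounds the position itself still allows a measurable value in this assay and the loss is confined to the cyano compound. Trifluoromethyl and chloro are not told apart here, with a 1.3-fold lower number from compound 1 to compound 4 (0.11 log units; within the scatter). With trifluoromethyl in place, propyl and cyclopentyl are not told apart either, with a 1.3-fold higher number from compound 2 to compound 4 (0.11 log units; within the scatter).

On these data alone, compound 3 remains a limit and not a number, so the full size of its step stays open: the limit of > 50000 nM in this assay, at which 1 of the 4 values shown sits. As far as these compounds go, what a methoxy group or an amine on this carbon would give also stays open.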